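The source may report more compounds than this note shows. Statements on the series, on what has been measured and on what is new or still open speak of the compounds shown alone.

Compound 1 `CC(C)(C)NC(=O)N1CC1C#N` is a cyanoaziridine urea that carries a tert-butyl group on the urea nitrogen. In a functional assay on MCF7 cells (Homo sapiens) for inhibition (a higher number here means a weaker inhibitor, a lower number a stronger inhibitor), compound 1 gives > 300000 nM, which is a limit of the measurement and not a number, so compound 1 stands at the weak end of everything shown here, at the limit of > 300000 nM in this assay, at which 1 of the 3 values shown sits. Two aryl ureas on the same core have also been measured. Compound 2 `N#CC1CN1C(=O)Nc1ccc(S(N)(=O)=O)cc1` gives > 15000 nM in this assay, again a limit rather than a number, at the limit of > 15000 nM in this assay, at which 1 of the 3 values shown sits. Within the data shown here, compound 3 `N#CC1CN1C(=O)Nc1cccnc1` gives 4200 nM in this assay, the only full number among the three.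

Compound 4 `CNC(=O)N1CC1C#N` has not yet been measured. It differs from compound 1 by methyl in place of tert-butyl on an amide-type nitrogen. Among the measured compounds shown here, no directly comparable pair with a measured step exists among the three compounds, and the two aryl ureas differ from compound 1 in more than one place, so only their values themselves can be read. Compound 1 sits at a limit, and a change from one small alkyl group to another on the urea nitrogen is expected to give a step of a number no higher from compound 1 to compound 4 (the limit leaves the size open), essentially none beyond the scatter. Compound 4 is therefore estimated at 300000 nM, with a range from 60000 nM to 1500000 nM, and most likely again only a limit.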

Compound 4, half-maximal inhibitory concentration: 27000 nM
Estimate against measurement, compound 4: 11-fold (1.05 log units) above; measured number below the stated range.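

In this assay, the urea nitrogen proves sensitive to the alkyl group it carries: methyl in place of tert-butyl gives an at least 11-fold lower number from compound 1 to compound 4 (1.04 log units; beyond the scatter), the first step that can be read among these compounds. Among these compounds, the earlier values gave no step at all, so they could not show that this position responds to a change of a single group, or that a small alkyl group here can bring a full number rather than a limit. The true size of the step remains open on one side, because the value for compound 1 is a limit and not a number: the limit of > 300000 nM in this assay, at which 1 of the 4 values shown sits.

The compounds shown leave open how the number moves between the two end points, which an ethyl or isopropyl group on the same nitrogen would help to settle. They also leave open whether this position accepts more than a plain alkyl group, a question that a longer chain ending in an amine or a carboxylic acid could address.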